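Losing the 1-methyl-1H-indol-5-yl group from compound 2

The source may hold more compounds than are shown below. What is called first, only, known or untested is meant among the compounds shown, and "the series" means these compounds.

Within the data shown here, in a functional assay on HeLa cells (Homo sapiens) for inhibition, read by CCK-8 assay, with a stated time of 48 h (on this read-out lower numbers stand for stronger inhibition and higher numbers for weaker inhibition), compound 2 (`COc1cc(-c2ccnc3cc(-c4ccc5c(ccn5C)c4)nn23)cc(OC)c1OC`) gives 19 nM, the only true number so far. Compound 1 (`COc1cc(-c2ccnc3cc(-c4cccc(C#N)c4)nn23)cc(OC)c1OC`) reaches only a limit of the assay, > 10000 nM. Compound 3 (`COc1cc(-c2ccnc3cc(-c4cccc(C)c4)nn23)cc(OC)c1OC`) carries 3-methylphenyl in place of 1-methyl-1H-indol-5-yl on an aromatic carbon. Among the measured compounds shown here, one measured step bears on this change: an at least 520-fold lower number from compound 1 to compound 2 (2.72 log units; beyond the scatter). It is large and beyond the scatter, and there 1-methyl-1H-indol-5-yl enters where here it leaves. A large step towards a higher number is therefore expected, an estimated 79-fold higher number from compound 2 to compound 3 (1.90 log units; beyond the scatter). For compound 3 the expected value is 1500 nM, with an estimated range from 150 nM to 10000 nM.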

Compound 3, half-maximal inhibitory concentration: 4230 nM
The estimate for compound 3 lay 2.8-fold (0.45 log units) below the measured number; measured number inside the range.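

In this assay, a second replacement for 1-methyl-1H-indol-5-yl also costs heavily, with a 220-fold higher number from compound 2 to compound 3 (2.35 log units; beyond the scatter), so the loss at this position is not tied to the 3-cyanophenyl group alone. The group on the phenyl ring also counts, with an at least 2.3-fold lower number from compound 1 to compound 3 (0.37 log units; beyond the scatter). Compound 1 stands only at a limit of the assay: the limit of > 10000 nM in this assay, at which 1 of the 3 values shown sits.

Which part of 1-methyl-1H-indol-5-yl carries its strength remains open, since its five-membered ring and its methyl are not tested apart. Also open, on these data alone, is how an amine or a carboxylic acid would behave in place of the methyl of compound 3.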